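Aryl substituent swap in the diaryl propyl amide series

The source may hold more compounds than are shown below. What is called first, only, known or untested is meant among the compounds shown, and "the series" means these compounds.

Measured so far in an assay for inhibition of Polyunsaturated fatty acid 5-lipoxygenase (Homo sapiens), read by HPLC, with stated times of 15 min and 10 min; on this read-out higher numbers stand for weaker inhibition and lower numbers for stronger inhibition:
- compound 1 `C[C@H](C#Cc1cccc(C(=O)NCCC(c2ccccc2)c2ccc(Cl)c(Cl)c2)c1)N(O)C(N)=O`: 96 nM
- compound 2 `CC(C#Cc1cccc(C(=O)NCc2ccc(F)cc2C(F)(F)F)c1)N(O)C(N)=O`: 1300 nM
- compound 3 `CC(C#Cc1cccc(C(=O)NCCC(c2ccccc2)c2ccc(F)cc2)c1)N(O)C(N)=O`: 160 nM

Compound 3 sits between the other two values in this assay. Its gap to compound 1 lies within the scatter of repeated measurements, so no order between the two can be read; its gap to compound 2 lies beyond the scatter, compound 2 giving the higher number.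

Compound 4 `CC(C#Cc1cccc(C(=O)NCCC(c2ccccc2)c2ccc(C(F)(F)F)cc2)c1)N(O)C(N)=O` differs from compound 3 in one place: trifluoromethyl in place of fluoro on an aromatic carbon. Among the compounds with values here, no pair among the measured compounds shows this same change, so nothing measured speaks directly to its size or direction. The two diaryl propyl amides measured, compound 1 and compound 3, lie within the scatter of each other despite different halogen substitution on the aryl ring, which gives no reason to expect a large shift from a further change at that position.

The step from compound 3 to compound 4 in this assay is therefore expected to be a 1.2-fold lower number from compound 3 to compound 4 (0.09 log units; within the scatter), within the scatter. For compound 4 the estimate is 130 nM, with a range from 50 nM to 350 nM.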

Compound 4, half-maximal inhibitory concentration: 150 nM
Estimate against measurement, compound 4: 1.2-fold (0.06 log units) below; the range from low to high includes it.
By their numbers in this assay, from the lowest: compounds 1, 4 and 3 (each within the scatter of the next); then compound 2.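

Replacing fluoro (1 heavy atom) with trifluoromethyl (4 heavy atoms) on the aromatic carbon para to a large group gives, in this assay, a 1.1-fold lower number from compound 3 to compound 4 (0.03 log units; within the scatter). Within the data shown here, this is the first pair to differ in one place, and it shows that the 4-fluorophenyl to 4-(trifluoromethyl)phenyl change leaves no readable shift in inhibition, despite the added heavy atoms. Nothing measured here bears on the reason for this result.

From the compounds shown here alone, whether a methoxy group, an amine or a carboxylic acid at this same place would also stay within the scatter remains open. Going by these compounds, it is also open whether the same fluoro to trifluoromethyl change would give a step of similar size on a different amide side chain, such as that of compound 2.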